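From 3,4-dichlorophenyl to methoxycarbonyl on a carbonyl carbon

The compounds below may be only part of what the source reports. "The series", "measured", "known", "first", "only" and "open" are said of these compounds alone.

In a functional assay on Vero cells (Chlorocebus sabaeus) for inhibition (a higher number here means a weaker inhibitor, a lower number a stronger inhibitor), compound 3 `COc1cc(/C=C/C(=O)c2cccc(NC(=O)c3ccc(Cl)c(Cl)c3)c2)ccc1O` gives > 50 ug/mL, which is a limit of the assay and not a number. Compound 1 `COc1cc(/C=C/C(=O)c2cccc(NC(=O)c3cc(Cl)cc(Cl)c3)c2)ccc1O` gives > 50 ug/mL, also a limit. Among the compounds with values here, compound 2 `COc1cc(/C=C/C(=O)c2cccc(NC(=O)c3ccc(Cl)cc3Cl)c2)ccc1O` gives 27.2 ug/mL, the only numerical reading so far.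

Compound 4 `COC(=O)C(=O)Nc1cccc(C(=O)/C=C/c2ccc(O)c(OC)c2)c1` carries methoxycarbonyl in place of 3,4-dichlorophenyl on a carbonyl carbon.

The measured steps only exchange one dichlorophenyl group for another, so none of them covers this replacement directly. The step of an at least 1.8-fold lower number from compound 1 to compound 2 (0.26 log units; that floor lies within the scatter) has a floor within the scatter. So does the step of an at least 1.8-fold higher number from compound 2 to compound 3 (0.26 log units; that floor lies within the scatter). The step that the two limits leave unreadable from compound 1 to compound 3 cannot be sized at all. The closest guide is therefore (the limit of > 50 ug/mL in this assay, at which 2 of the 3 values shown sit), with compound 2 as the one exception.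

On that basis, no step beyond the scatter is expected in this assay, and no direction can be assigned with confidence. The expected step is an at least 1.1-fold lower number from compound 3 to compound 4 (0.04 log units; that floor lies within the scatter), and it is measured against a limit rather than a number. The estimated value for compound 4 is 45 ug/mL, with an expected range of 18 ug/mL to 100 ug/mL.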

Compound 4, half-maximal inhibitory concentration: 3.55 ug/mL
Estimate against measurement, compound 4: 13-fold (1.10 log units) above, outside the stated range (below it).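

In this assay, the place on a carbonyl carbon whose other neighbour is the amide-type nitrogen can move the read-out well beyond the scatter, which no exchange among the dichlorophenyl groups showed: methoxycarbonyl in place of 3,4-dichlorophenyl gives an at least 14-fold lower number from compound 3 to compound 4 (1.14 log units; beyond the scatter), and in place of 3,5-dichlorophenyl it gives an at least 14-fold lower number from compound 1 to compound 4 (1.14 log units; beyond the scatter). Against the only earlier numerical reading, methoxycarbonyl in place of 2,4-dichlorophenyl gives a 7.7-fold lower number from compound 2 to compound 4 (0.88 log units; beyond the scatter), so the gain does not rest on limits alone, and compound 4 shows that a lower number in this assay does not need an aromatic ring at this place. Compound 1 and compound 3 each remain at a limit of the assay, so the two larger steps are floors and their true size stays unread: the limit of > 50 ug/mL in this assay, at which 2 of the 4 values shown sit.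

The replacement removes the ring and both chlorines and brings in methoxycarbonyl in a single change, and the compounds shown cannot separate these parts. Going by these compounds, whether the reading holds with a carboxylic acid, an ethoxycarbonyl group, a primary amide or a plain methyl group on this carbonyl carbon remains open.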